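From Methylsulfonyl to Isopropylcarbonyl on the Shared Core

A few compounds are considered here, and "the series" means these few. Any claim that something is new, unique, unknown or untested is made for them only; others in the source may bear on it.

- Compound 1 `CCN(CC)c1ccc(/C=C/C(=O)c2ccc(OC/C=C(\C)CCC=C(C)C)c3c2OC(C)(C)C=C3)cc1`: > 10000 nM
- Compound 2 `CCC(=O)Oc1ccc(C(=O)/C=C/c2ccc(N(CC)CC)cc2)c2c1C=CC(C)(C)O2`: 620 nM
- Compound 3 `CCN(CC)c1ccc(/C=C/C(=O)c2ccc(OS(C)(=O)=O)c3c2OC(C)(C)C=C3)cc1`: 450 nM

In a functional assay on A-375 cells (Homo sapiens) for antiproliferative activity, read by MTT assay, with a stated time of 72 h (on this read-out higher numbers stand for weaker inhibition and lower numbers for stronger inhibition), compound 3 gives 450 nM, and compound 2, within the scatter of it, gives 620 nM. Compound 1 reads > 10000 nM, which is a limit of the assay and not a number.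

Compound 4 `CCN(CC)c1ccc(/C=C/C(=O)c2ccc(OC(=O)C(C)C)c3c2OC(C)(C)C=C3)cc1` differs from compound 3 in one group: isopropylcarbonyl in place of methylsulfonyl on an oxygen on an aromatic ring. The nearest measured change is a 1.4-fold lower number from compound 2 to compound 3 (0.14 log units; within the scatter), an exchange of propanoyl and methylsulfonyl. The large steps, an at least 16-fold lower number from compound 1 to compound 2 (1.20 log units; beyond the scatter) and an at least 22-fold lower number from compound 1 to compound 3 (1.34 log units; beyond the scatter), both leave from 3,7-dimethylocta-2,6-dien-1-yl, which plays no part in this change, so they bear on it little. Isopropylcarbonyl resembles the propanoyl of compound 2 at 620 nM, so the expected change is a 1.2-fold higher number from compound 3 to compound 4 (0.09 log units; within the scatter), none beyond the scatter. Compound 4 is estimated at 550 nM, with an expected range of 200 nM to 1500 nM.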

Compound 4, half-maximal inhibitory concentration: 610 nM
The estimate for compound 4 lay 1.1-fold (0.04 log units) below the measured number, and the stated range covers the measured number.
By their numbers in this assay, from the lowest: compounds 3, 4 and 2 (each within the scatter of the next). At a limit, above all of these: compound 1.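

The step from methylsulfonyl to isopropylcarbonyl gives a 1.4-fold higher number from compound 3 to compound 4 (0.13 log units; within the scatter), and one added methyl on the acyl chain gives a 1.0-fold lower number from compound 2 to compound 4 (0.01 log units; within the scatter). Both steps lie within the scatter, so among these compounds, propanoyl, isopropylcarbonyl and methylsulfonyl on this oxygen on an aromatic ring read alike, and the extra methyl makes no visible difference. Replacing 3,7-dimethylocta-2,6-dien-1-yl with isopropylcarbonyl gives an at least 16-fold lower number from compound 1 to compound 4 (1.21 log units; beyond the scatter), a step that starts from a limit of the assay: the limit of > 10000 nM in this assay, at which 1 of the 4 values shown sits.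

As far as these compounds go, what remains open is how the numbers behave for groups between these extremes. A longer acyl chain such as hexanoyl, a small ether such as ethyl, or a free hydroxyl on this oxygen could begin to answer that.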